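From Bromophenyl to Nitrophenyl on the Shared Core

The source may hold more compounds than are shown below. What is called first, only, known or untested is meant among the compounds shown, and "the series" means these compounds.

Measured compounds:
Compound 1 `O=C(CSc1nc(Nc2ccccc2)c2ccccc2n1)Nc1ccccc1Br` gives 18600 nM in a functional assay on MGC-803 cells (Homo sapiens) for inhibition, read by MTT assay, with a stated time of 72 h; on this read-out lower numbers stand for stronger inhibition and higher numbers for weaker inhibition.
Compound 2 `O=C(CSc1nc(Nc2ccccc2)c2ccccc2n1)Nc1ccc(C(F)(F)F)cc1` gives 8670 nM in this assay.
Compound 3 `C=CC(=O)Nc1cccc(NC(=O)CSc2nc(Nc3ccccc3Br)c3ccccc3n2)c1` gives 12800 nM in this assay.

Compound 3 stands second highest of the three numbers. Its nearest neighbour is compound 1, whose value lies within the scatter of it, and compound 2 lies on the other side, also within the scatter. Among the measured compounds shown here, the only step with a single change, a 2.1-fold lower number from compound 1 to compound 2 (0.33 log units; beyond the scatter), concerns the group on the amide-type nitrogen, a different place from the one changed here.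

Compound 4 `C=CC(=O)Nc1cccc(NC(=O)CSc2nc(Nc3cccc([N+](=O)[O-])c3)c3ccccc3n2)c1` differs from compound 3 by 3-nitrophenyl in place of 2-bromophenyl on a nitrogen on an aromatic ring. For the measured compounds named here, no measured pair alters this group on the nitrogen on the aromatic ring, so the step to compound 4 has no direct precedent in these data. Going by the values given here, with only one modest step elsewhere, and compound 3 sitting among values that are mutually within the scatter, the change to compound 4 is expected to give a 1.1-fold lower number from compound 3 to compound 4 (0.03 log units; within the scatter), a move not clearly beyond the scatter in either direction. Compound 4 is therefore estimated at 12000 nM in this assay, with a range from 4500 nM to 32000 nM.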

Compound 4, half-maximal inhibitory concentration: > 50000 nM
Compound 4 was reported as a limit; the forecaster's own chance of this, stated with the estimate: 5%; middle value at least 4.1-fold (0.61 log units) away from the limit.
By their numbers in this assay, from the lowest: compounds 2, 3 and 1 (each within the scatter of the next, the first and the last beyond it). At a limit, above all of these: compound 4.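

In this assay compound 4 gives > 50000 nM, which is a limit of the assay and not a number. The change from (2-bromophenyl)amino to (3-nitrophenyl)amino is the only one shown at the nitrogen on an aromatic ring, and it gives an at least 3.9-fold higher number from compound 3 to compound 4 (0.59 log units; beyond the scatter), so inhibition at this place does depend on the group carried there, which the earlier compounds could not show, as their one single-change step, a 2.1-fold lower number from compound 1 to compound 2 (0.33 log units; beyond the scatter), lay on the amide-type nitrogen. The step from 2-bromophenyl to 3-nitrophenyl therefore has a lower bound only, and its full size stays unknown: the limit of > 50000 nM in this assay, at which 1 of the 4 values shown sits.

As far as these compounds go, what stays open is whether this weaker inhibition goes with the nitro group itself or with the different place of the substituent on the phenyl ring, a question that 3-bromophenyl or 2-nitrophenyl at this nitrogen would address. Also open, from the compounds shown here alone, is how an amine or a carboxylic acid in that same place on the phenyl ring would read in this assay.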